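Hydroxy to chloro near an assay limit

The compounds below may be only part of what the source reports. "The series", "measured", "known", "first", "only" and "open" are said of these compounds alone.

In an ADME assay on Raji cells (Homo sapiens) for cytotoxicity, with a stated time of 72 h (on this read-out lower numbers stand for an effect already at smaller amounts and higher numbers for an effect only at larger amounts of compound), compound 3 `Cc1cc(NC(=O)Nc2ccc(O)cc2)c2ccccc2n1` reads > 25000 nM as a limit of the assay and not a number. Compound 1 `Cc1cc(NC(=O)Nc2ccccc2N)c2ccccc2n1` reads > 25000 nM as a limit too. So the limit of > 25000 nM in this assay, at which 2 of the 3 values shown sit, is where compound 3 stands, with no exact figure for it. Compound 2 `COC(=O)c1ccc(NC(=O)Nc2cc(C)nc3ccccc23)cc1` gives a true number, 17000 nM in this assay on the same scale.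

Compound 4 `Cc1cc(NC(=O)Nc2ccc(Cl)cc2)c2ccccc2n1` carries chloro in place of hydroxy on an aromatic carbon. The closest measured swap, hydroxy in place of methoxycarbonyl on an aromatic carbon, gave an at least 1.4-fold higher number from compound 2 to compound 3 (0.16 log units; that floor lies within the scatter) and so says little. The other swap, 4-hydroxyphenyl in place of 2-aminophenyl on an amide-type nitrogen, gave a step that the two limits leave unreadable from compound 1 to compound 3 and offers no size. Neither step shows a move beyond the scatter. Only a modest move toward lower numbers is therefore expected, estimated as an at least 1.3-fold lower number from compound 3 to compound 4 (0.14 log units; that floor lies within the scatter) in this assay and possibly hidden by the limit. The estimate for compound 4 is 18000 nM with an expected range from 7000 nM to 25000 nM and a limit reading remains possible.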

Compound 4, half-maximal effective concentration: > 25000 nM
Compound 4 ended at the assay's limit (the forecaster's own chance of this, stated with the estimate: 45%); middle value at least 1.3-fold (0.14 log units) from the limit.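

In this assay, the reading of compound 4 is a limit and not a number, so chloro at this place, para to a large group, gives no more of a readable result than hydroxy did, and the steps to compound 4 from compound 3 and compound 1 cannot be read. For the compounds shown here, the one step that can be read is an at least 1.4-fold higher number from compound 2 to compound 4 (0.16 log units; that floor lies within the scatter). The new point is that a group with 0 hydrogen-bond donors and 0 hydrogen-bond acceptors also leaves the compound at the limit, and the set now stands as follows: the limit of > 25000 nM in this assay, at which 3 of the 4 values shown sit.

As far as these compounds go, how far hydroxy and chloro differ past that limit stays unknown. From the compounds shown here alone, whether a carboxylic acid or a longer alkyl chain at this place would bring the reading down to a true number also stays open.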